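Replacing the 4-methoxyphenyl group of compound 1

The source may hold more compounds than are shown below. What is called first, only, known or untested is meant among the compounds shown, and "the series" means these compounds.

In a functional assay on K562 cells (Homo sapiens) for inhibition, read by trypan blue exclusion, with a stated time of 72 h (on this read-out lower numbers stand for stronger inhibition and higher numbers for weaker inhibition), compound 1 (`COc1ccc(Nc2ncc3cc(S(=O)(=O)c4ccc(C)cc4)c(=O)n(C)c3n2)cc1`) gives 75000 nM, the highest number of the three measured. Compound 2 (`COc1ccc(Nc2ncc3cc(S(=O)(=O)c4ccc(Cl)cc4)c(=O)n(C)c3n2)cc1`) gives 15000 nM. The unmeasured compound 4 (`Cc1ccc(S(=O)(=O)c2cc3cnc(Nc4cnc5[nH]ccc5c4)nc3n(C)c2=O)cc1`) differs from compound 1 by one change: a group of 9 heavy atoms (7 carbon, 2 nitrogen; one five-membered aromatic ring with 1 hetero atom, one six-membered aromatic ring with 1 hetero atom) in place of a group of 8 heavy atoms (7 carbon, 1 oxygen; one six-membered aromatic ring of carbon only), on a nitrogen on an aromatic ring. Within the data shown here, the only measured single change, a 5.0-fold lower number from compound 1 to compound 2 (0.70 log units; beyond the scatter), lies at another place and so bears on this one only weakly. Among the measured compounds shown here, no measured step isolates the replacement. Compound 3 (`Cn1ccc2cc(Nc3ncc4cc(S(=O)(=O)c5ccc(F)cc5F)c(=O)n(C)c4n3)ccc21`) also lacks the 4-methoxyphenyl group and gives 750 nM, but it differs elsewhere too. A sizeable move to a lower number is therefore expected, smaller than that gap: a 13-fold lower number from compound 1 to compound 4 (1.10 log units; beyond the scatter). Compound 4 is estimated at 6000 nM, with an expected range from 1000 nM to 30000 nM.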

Compound 4, half-maximal inhibitory concentration: 15000 nM
Beside the measured number, compound 4's estimate is 2.5-fold (0.40 log units) below it; the measured number falls inside the stated range.
By their numbers in this assay, from the lowest: compound 3; then compounds 2 and 4 (each within the scatter of the next); then compound 1.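

With the rest of compound 1 unchanged, exchanging the 4-methoxyphenyl group on the nitrogen gives a 5.0-fold lower number from compound 1 to compound 4 (0.70 log units; beyond the scatter) in this assay. Among these compounds, this is the first measured step at this place, and it shows that the two-ring group, which carries a hydrogen-bond donor, is tolerated there with a modest gain. No measurement shown explains this step. The compounds shown leave open how a piperazine or a morpholine would fare in place of the 4-methoxyphenyl group. They also leave open whether this step and the chloro-for-methyl step would add up in one compound.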